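A few compounds are considered here, and "the series" means these few. Any claim that something is new, unique, unknown or untested is made for them only; others in the source may bear on it.

Compound 2 `O=C(O)Cc1nn(Cc2cn3cc(OCC4CC4)c(Cl)cc3n2)c2ccccc2c1=O` gives 4.8 nM in a functional assay on HFL1 cells for antagonist activity at sphingosine 1-phosphate receptor 2 (Homo sapiens), read by ELISA, with a stated time of 24 h (on this read-out higher numbers stand for weaker inhibition and lower numbers for stronger inhibition), the lowest of the two numbers recorded so far. Among the compounds with values here, its only measured neighbour is compound 1 `COC(C(=O)O)c1nn(Cc2cn3cc(OCC4CC4)c(Cl)cc3n2)c2ccccc2c1=O`, which in this assay gives 94 nM; the step of a 20-fold lower number from compound 1 to compound 2 (1.29 log units; beyond the scatter) is the single measured comparison available. Compound 3 `O=C(O)C1(c2nn(Cc3cn4cc(OCC5CC5)c(Cl)cc4n3)c3ccccc3c2=O)CC1` has not yet been measured in this assay. It differs from compound 2 by 1-carboxycyclopropyl in place of carboxymethyl on an aromatic carbon. Within the data shown here, the one measured step that bears on this change is a 20-fold lower number from compound 1 to compound 2 (1.29 log units; beyond the scatter), in which a group on the saturated chain carbon bound to the aromatic carbon and the carbonyl carbon was replaced by hydrogen and the number fell by a large margin. Compound 3 again carries substitution at that same chain carbon, now closed into a three-membered ring of carbon only, so a move back toward a higher number is expected for compound 3, although the entering group is not the one that left in the earlier step and a smaller shift is therefore expected. For compound 3 a step of a 6.3-fold higher number from compound 2 to compound 3 (0.80 log units; beyond the scatter) is expected. Compound 3 is accordingly estimated at 30 nM, with a range from 8 nM to 150 nM.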

Compound 3, half-maximal inhibitory concentration: 28 nM
Compound 3: middle estimate off by 1.1-fold (0.03 log units), on the high side, and the stated range covers the measured number.
By their numbers in this assay, from the lowest: compound 2; then compound 3; then compound 1.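

In this assay, replacing carboxymethyl with 1-carboxycyclopropyl gives a 5.8-fold higher number from compound 2 to compound 3 (0.77 log units; beyond the scatter), so a rise in the number on substitution at the chain carbon is now seen with a second, quite different group, and among these three compounds the unsubstituted carboxymethyl of compound 2 gives the lowest number. The two substituted groups are not interchangeable either: exchanging carboxy(methoxy)methyl for 1-carboxycyclopropyl gives a 3.4-fold lower number from compound 1 to compound 3 (0.53 log units; beyond the scatter), which shows that the size of the rise depends on what sits on that carbon and not merely on the presence of a substituent. No measurement is available that accounts for either step.

As far as these compounds go, all three compounds keep a carboxylic acid on this chain, so it remains open whether an amide or a tetrazole could stand in its place, or how a longer chain such as carboxyethyl would read. Also open, from the compounds shown here alone, is whether a single methyl or two methyl groups on the chain carbon would behave like the closed cyclopropane ring, which would separate substitution from ring closure.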